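Working notes: a second chloro added to compound 2

The compounds below may be only part of what the source reports. "The series", "measured", "known", "first", "only" and "open" are said of these compounds alone.

Measured so far:
compound 1 `N#C/C(=C\N1CCN(C(=O)c2ccco2)C1=S)C(=O)c1ccccc1` gives 68200 nM
compound 2 `O=CN1CCN(c2ccc(Cl)cc2)C1=S` gives 20000 nM

In a functional assay on SNB-75 cells (Homo sapiens) for inhibition, read by sulforhodamine B assay, with a stated time of 48 h (a higher number here means a weaker inhibitor of growth, a lower number a stronger inhibitor of growth), compound 1 gives 68200 nM and compound 2 gives 20000 nM. Compound 2 has the lower of the two numbers, and the gap to compound 1 lies beyond the scatter, so of this pair compound 2 is the stronger inhibitor of growth. The two structures differ in several places at once, so the two values show no more than that.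

Compound 3 `O=CN1CCN(c2ccc(Cl)c(Cl)c2)C1=S` is not yet measured. It differs from compound 2 by chloro in place of hydrogen on an aromatic carbon. Among the compounds with values here, no pair of measured compounds is separated by this change alone, so nothing measured tells how far a second chloro moves the number in this assay. With compound 2 as the only anchor, a small step at most is expected, leaning toward a lower number, and possibly none beyond the scatter. The expected step in this assay is a 1.4-fold lower number from compound 2 to compound 3 (0.15 log units; within the scatter). The estimate for compound 3 in this assay is 14000 nM, within 5000 nM to 40000 nM.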

Compound 3, concentration for 50% growth inhibition: 17500 nM
Compound 3: the middle estimate sits 1.3-fold (0.10 log units) below what was measured, within the range that was stated.
By their numbers in this assay, from the lowest: compounds 3 and 2 (each within the scatter of the next); then compound 1.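

In this assay, chloro in place of hydrogen on an aromatic carbon, ortho to a chloro group and meta to a group of 8 heavy atoms, gives a 1.1-fold lower number from compound 2 to compound 3 (0.06 log units; within the scatter). Within the data shown here, this is the first change that can be read alone, since the earlier pair differed in several places at once, and it shows that this position takes a chloro with no shift of the number beyond the scatter, so compound 3 stands level with compound 2 within the scatter. No measurement at hand speaks to the reason for this flat step.

Among these compounds, whether a different group at this position, such as an amine, a carboxylic acid or a longer chain like propyl, would move the number beyond the scatter remains open, since hydrogen and chloro are the only two groups compared here. From the compounds shown here alone, it is also open whether the same exchange on another carbon of this ring, or on a different version of the shared core, would give a similarly small step, as a single pair sets no pattern.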